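Methoxy for bromo on a very short-lived compound

The source may hold more compounds than are shown below. What is called first, only, known or untested is meant among the compounds shown, and "the series" means these compounds.

Compound 1 `Cc1ccc(C)c(-c2nc(CN3CCC(C(=O)NCCCN4C[C@H](C)C[C@H](C)C4)CC3)c(C)o2)c1`, compound 2 `Cc1oc(-c2ccc(Cl)c(Cl)c2)nc1CN1CCC(C(=O)NCCCN2C[C@H](C)C[C@H](C)C2)CC1` and compound 3 `Cc1oc(-c2c(Cl)cccc2Br)nc1CN1CCC(C(=O)NCCCN2C[C@H](C)C[C@H](C)C2)CC1` differ only in their aryl group, and all three were tested in an ADME assay on microsomes from liver (Rattus norvegicus) for metabolic stability, read by LC-MS, using NADPH, at 37 degrees C; on this read-out lower numbers stand for a shorter-lived compound and higher numbers for a longer-lived compound. Compound 1 gives 0.5 h. Compound 2 gives > 0.5 h, which is a limit of the assay and not a number. Compound 3, which carries 2-bromo-6-chlorophenyl, gives 0.0233 h, the lowest value of the three. The measured steps to this group are a 21-fold lower number from compound 1 to compound 3 (1.33 log units; beyond the scatter) and an at least 21-fold lower number from compound 2 to compound 3 (1.33 log units; beyond the scatter), both large and beyond the scatter.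

Compound 4 `COc1cccc(Cl)c1-c1nc(CN2CCC(C(=O)NCCCN3C[C@H](C)C[C@H](C)C3)CC2)c(C)o1` has methoxy in place of bromo on an aromatic carbon, giving 2-chloro-6-methoxyphenyl (methoxy in place of bromo on an aromatic carbon). For the measured compounds named here, no measured step isolates this swap, since the steps above exchange whole aryl groups. The new group is nonetheless closer to that of compound 3 than to those of compound 1 or compound 2, so compound 4 is expected to stay near compound 3, which gives 0.0233 h. The expected change is small and upward, a 1.7-fold higher number from compound 3 to compound 4 (0.23 log units; within the scatter), within the scatter. Compound 4 is estimated at 0.04 h, with an expected range from 0.012 h to 0.2 h.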

Compound 4, half-life: 0.055 h
For compound 4 the middle estimate is 1.4-fold (0.14 log units) below the measured one; low and high end bracket the measured number.
By their numbers in this assay, from the lowest: compound 3; then compound 4; then compound 1.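

In this assay, methoxy in place of bromo, on an aromatic carbon ortho to a large group, is the first change shown that touches this one position alone, and it gives a 2.4-fold higher number from compound 3 to compound 4 (0.37 log units; beyond the scatter). For the compounds shown here, the single swap therefore moves the half-life, but only part of the way: with 2-chloro-6-methoxyphenyl the number still shows a 9.1-fold lower number from compound 1 to compound 4 (0.96 log units; beyond the scatter). Compound 2 stands at a limit and not at a number, so its comparison, an at least 9.0-fold lower number from compound 2 to compound 4 (0.95 log units; beyond the scatter), fixes only a minimum size: the limit of > 0.5 h in this assay, at which 1 of the 4 values shown sits.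

The compounds shown leave open whether ethoxy, hydroxy or fluoro at this position would move the half-life further than methoxy does. They also leave open what part the chloro group shared by compound 3 and compound 4 plays, as neither compound has a partner lacking it.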